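Exchanging Methoxy for Dimethylamino at the Chain Carbon

The source may hold more compounds than are shown below. What is called first, only, known or untested is meant among the compounds shown, and "the series" means these compounds.

Compound 1 `[N-]=[N+]=Nc1c(F)c(N)c2c(=O)cc(-c3ccc(N)c(F)c3)oc2c1F` and compound 2 `COCc1c(F)c(N)c2c(=O)cc(-c3ccc(N)c(F)c3)oc2c1F` share one core and differ at a single aromatic carbon. In a functional assay on MCF7 cells (Homo sapiens) for cytotoxicity, read by neutral red uptake, with a stated time of 3 days (a lower number here means a stronger inhibitor, a higher number a weaker inhibitor), compound 1 gives 460 nM, and compound 2 gives 46 nM, the lowest of the two numbers measured. For the measured compounds named here, the step of a 10-fold lower number from compound 1 to compound 2 (1.00 log units; beyond the scatter) is the only measured step. Compound 3 `CN(C)Cc1c(F)c(N)c2c(=O)cc(-c3ccc(N)c(F)c3)oc2c1F` differs from compound 2 by dimethylamino in place of methoxy on a saturated chain carbon bound to an aromatic carbon. Going by the values given here, no measured step concerns this exchange, so that earlier step gives no direct guide. The expected step of a 1.3-fold higher number from compound 2 to compound 3 (0.12 log units; within the scatter) is therefore within the scatter. The estimate for compound 3 is 60 nM, ranging from 15 nM to 250 nM.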

Compound 3, half-maximal inhibitory concentration: 72 nM
The estimate for compound 3 lay 1.2-fold (0.08 log units) below the measured number, and the stated range covers the measured number.
By their numbers in this assay, from the lowest: compounds 2 and 3 (each within the scatter of the next); then compound 1.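

In this assay, dimethylamino in place of methoxy on a saturated chain carbon bound to an aromatic carbon gives a 1.6-fold higher number from compound 2 to compound 3 (0.19 log units; within the scatter), so this exchange leaves the number unchanged within the scatter. Putting (dimethylamino)methyl in place of azido gives a 6.4-fold lower number from compound 1 to compound 3 (0.81 log units; beyond the scatter), a step in the same direction as a 10-fold lower number from compound 1 to compound 2 (1.00 log units; beyond the scatter). Nothing available explains this tolerance.

Going by these compounds, whether a carboxylic acid, a hydroxyl or a longer chain would be tolerated at the chain carbon remains open. So does whether a primary amine there would fit the same picture.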